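Trimming a tert-butyl on a sulfonamide: compound 3 to compound 4

This account rests on a few compounds, and the source may have more. Where it says the series, first, only, none or still open, it means among the compounds named here.

Measured so far:
- compound 1, `CCOC(=O)N1CCC[C@H](S(=O)(=O)c2ccc(S(=O)(=O)N(CC)CC)cc2)C1`: > 30000 nM
- compound 2, `CCOC(=O)[C@@H]1CCCN(S(=O)(=O)c2ccc(S(=O)(=O)N(CC)CC)cc2C)C1`: 5600 nM
- compound 3, `CC(C)c1noc(N2CCN(C(=O)[C@@H]3CCCN(S(=O)(=O)c4ccc(S(=O)(=O)NC(C)(C)C)cc4)C3)CC2)n1`: 2600 nM

All three were tested in a functional assay on BXPC-3 cells (Homo sapiens) for inhibition, read by MTT assay, with a stated time of 7 days; on this read-out higher numbers stand for weaker inhibition and lower numbers for stronger inhibition. Compound 1 gives > 30000 nM, which is a limit of the assay and not a number (the limit of > 30000 nM in this assay, at which 1 of the 3 values shown sits). Compound 2 gives 5600 nM. Compound 3 gives 2600 nM, the lowest of the two numbers shown, and its gap to compound 2 lies beyond the scatter.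

Compound 4, `CC(C)NS(=O)(=O)c1ccc(S(=O)(=O)N2CCC[C@@H](C(=O)N3CCN(c4nc(C(C)C)no4)CC3)C2)cc1`, has not yet been measured. It differs from compound 3 in one place: hydrogen in place of methyl on a saturated chain carbon bound to two saturated chain carbons and a sulfonamide nitrogen. The change sits far from the core, on the sulfonamide substituent, and removes one carbon. Among the measured compounds shown here, no measured pair in this set shows this kind of step, so its size can only be guessed from the change itself: a small step is expected, most likely within the scatter, with no strong pull in either direction.

Compound 4 is therefore estimated at 3500 nM, within 1200 nM to 10000 nM, and the expected step of a 1.3-fold higher number from compound 3 to compound 4 (0.13 log units; within the scatter) is close to none.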

Compound 4, half-maximal inhibitory concentration: 2600 nM
Compound 4: the middle estimate sits 1.3-fold (0.13 log units) above what was measured, within the range that was stated.
By their numbers in this assay, from the lowest: compounds 3 and 4 (each within the scatter of the next); then compound 2. At a limit, above all of these: compound 1.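

In this assay, cutting the tert-butyl down to isopropyl on the sulfonamide nitrogen gives no change at the digits printed from compound 3 to compound 4 (within the scatter), and this is the only pair shown that differs in one place. Among the compounds shown here, it offers the first direct reading at this position: here, replacing a methyl with hydrogen on the saturated chain carbon leaves the read-out unchanged within the scatter. Nothing measured here gives a reason for this flat step.

The compounds shown leave open what other groups would do on the same sulfonamide nitrogen, such as a plain hydrogen, a methyl, a longer chain, or a chain ending in an amine or a carboxylic acid. For the compounds shown here, with tert-butyl and isopropyl as the only two groups compared, a single pair cannot show how far this flat result extends.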